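From Methylsulfonyl to Nitro on the Shared Core

This account rests on a few compounds, and the source may have more. Where it says the series, first, only, none or still open, it means among the compounds named here.

Compound 1 `Cc1cnc(Nc2ccc(C(C)C)cc2)nc1Nc1nc2ccccc2s1` and compound 2 `Cc1cnc(Nc2ccc(S(C)(=O)=O)cc2)nc1Nc1nc2ccccc2s1` share one core and differ in a single group on an aromatic carbon. In a functional assay on MDA-MB-231 cells (Homo sapiens) for antiproliferative activity, read by MTT assay, with a stated time of 48 h (a higher number here means a weaker inhibitor, a lower number a stronger inhibitor), compound 1 gives > 50000 nM, which is a limit of the assay rather than a number. In this assay compound 2 gives 14800 nM. For the measured compounds named here, compound 2 thus stands as the only compound with an actual number, the other value being a limit. Going by the values given here, the only measured step is an at least 3.3-fold lower number from compound 1 to compound 2 (0.52 log units; beyond the scatter); it rests on (the limit of > 50000 nM in this assay, at which 1 of the 2 values shown sits), so its true size is known only as a lower bound. Compound 3 `Cc1cnc(Nc2ccc([N+](=O)[O-])cc2)nc1Nc1nc2ccccc2s1` carries nitro in place of methylsulfonyl on an aromatic carbon. Nothing measured tells how nitro compares with methylsulfonyl at this place, so the expected step of a 1.0-fold higher number from compound 2 to compound 3 (0.01 log units; within the scatter) is none beyond the scatter. Compound 3 is therefore estimated to give 15000 nM, within 5000 nM to 45000 nM.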

Compound 3, half-maximal inhibitory concentration: 22500 nM
Compound 3: the middle estimate sits 1.5-fold (0.18 log units) below what was measured; measured number inside the range.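

Placing nitro where methylsulfonyl stood gives a 1.5-fold higher number from compound 2 to compound 3 (0.18 log units; within the scatter), so in this assay these two groups cannot be told apart at this place on the ring. Nitro also improves on isopropyl, with an at least 2.2-fold lower number from compound 1 to compound 3 (0.34 log units; beyond the scatter), which means the lower number seen for compound 2 is no longer tied to methylsulfonyl alone: two different groups in place of isopropyl both give a lower number. The value of compound 1 is a limit, so the true size of both steps away from it is known only as a lower bound: the limit of > 50000 nM in this assay, at which 1 of the 3 values shown sits.

The compounds shown leave open how other groups at this place, such as an amine, a carboxylic acid or a longer chain, would read in this assay. They also do not tell why nitro and methylsulfonyl both give lower numbers than isopropyl.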